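The source may report more compounds than this note shows. Statements on the series, on what has been measured and on what is new or still open speak of the compounds shown alone.

Compounds measured in a functional assay on A-431 cells (Homo sapiens) for antiproliferative activity, read by MTT assay, with a stated time of 72 h; on this read-out higher numbers stand for weaker inhibition and lower numbers for stronger inhibition:
Compound 1 `O=C(Nc1cccc(CN2CCCC2)c1)Nc1ccc2ncnc(Nc3cccc(C(F)(F)F)c3)c2c1` gives 1230 nM.
Compound 2 `COc1ccc(NC(=O)Nc2ccc3ncnc(Nc4cccc(C(F)(F)F)c4)c3c2)cc1` gives 4950 nM.
Compound 3 `CN1CCN(CCNC(=O)Nc2ccc3ncnc(Nc4cccc(C(F)(F)F)c4)c3c2)CC1` gives only a limit, > 10000 nM.

Compound 1 has the lowest number of the three, and the steps away from it are a 4.0-fold higher number from compound 1 to compound 2 (0.60 log units; beyond the scatter) and an at least 8.1-fold higher number from compound 1 to compound 3 (0.91 log units; beyond the scatter). Between compound 2 and compound 3 the step is an at least 2.0-fold higher number from compound 2 to compound 3 (0.30 log units; that floor lies within the scatter), so these two cannot be ranked against each other. Compound 3 stands clearly beyond compound 1, and its value is a limit of this assay rather than a number (the limit of > 10000 nM in this assay, at which 1 of the 3 values shown sits).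

Compound 4 `C[C@@H](Nc1ncnc2ccc(NC(=O)NCCN3CCN(C)CC3)cc12)c1ccccc1` is not yet measured. It differs from compound 3 in one place: 1-phenylethyl in place of 3-(trifluoromethyl)phenyl on a nitrogen on an aromatic ring. None of the three measured steps touches this position; all three swap the group on the amide-type nitrogen while the 3-(trifluoromethyl)phenyl stays fixed. They therefore give no guide to the size or direction of the step from compound 3 to compound 4 in this assay.

Going by the values given here, with no bearing step and compound 3 already at the limit, compound 4 is expected to give a value near that limit, estimated at 10000 nM, in a range from 3000 nM to 30000 nM. The step this estimate means, a number no higher from compound 3 to compound 4 (the limit leaves the size open), is expected to be small, with a fair chance that only a limit is reported again.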

Compound 4, half-maximal inhibitory concentration: > 10000 nM
Compound 4: no number, only a limit; the forecaster's own chance of this, stated with the estimate: 55%; the middle value lies on the limit itself.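

In this assay compound 4 gives only a limit, as compound 3 does, so no step between these two can be read: the limit of > 10000 nM in this assay, at which 2 of the 4 values shown sit.

The compounds shown leave open whether 1-phenylethyl in place of 3-(trifluoromethyl)phenyl on a nitrogen on an aromatic ring changes the activity at all, and in which direction.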